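Compound 2 to compound 3: substitution on an aromatic nitrogen

A few compounds are considered here, and "the series" means these few. Any claim that something is new, unique, unknown or untested is made for them only; others in the source may bear on it.

Measured in a functional assay on A549 cells (Homo sapiens) for antiproliferative activity, read by MTT assay, with a stated time of 24 h; a lower number here means a stronger inhibitor, a higher number a weaker inhibitor:
- compound 1 `Cc1ccc(-c2nn(-c3ccccc3)cc2-c2nc3ccccc3[nH]2)cc1` gives 4010 nM
- compound 2 `FC(F)(F)c1ccc(-c2nn(-c3ccccc3)cc2-c2nc3ccccc3[nH]2)cc1` gives 3620 nM

Compound 2 has the lower number of the two, but a 1.1-fold lower number from compound 1 to compound 2 (0.04 log units; within the scatter) stays within the scatter, so the pair shows no real separation. Compound 3 `COc1ccc(S(=O)(=O)n2c(-c3cn(-c4ccccc4)nc3-c3ccc(C(F)(F)F)cc3)nc3ccccc32)cc1` has (4-methoxyphenyl)sulfonyl in place of hydrogen on an aromatic nitrogen. Among the compounds with values here, that one measured step concerns an aromatic carbon, and no measured step covers this nitrogen, so the expectation is only a tentative one, towards a lower number in this assay. The expected step is a 2.4-fold lower number from compound 2 to compound 3 (0.38 log units; beyond the scatter), with wide uncertainty. For compound 3 the estimated value is 1500 nM (expected range 250 nM to 6000 nM).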

Compound 3, half-maximal inhibitory concentration: 170 nM
Beside the measured number, compound 3's estimate is 8.8-fold (0.95 log units) above it; measured number outside the range, below it.
By their numbers in this assay, from the lowest: compound 3; then compounds 2 and 1 (each within the scatter of the next).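

In this assay, within the data shown here, (4-methoxyphenyl)sulfonyl in place of hydrogen on an aromatic nitrogen gives a 21-fold lower number from compound 2 to compound 3 (1.33 log units; beyond the scatter) and marks this nitrogen as a place where substitution moves the number well beyond the scatter, which the single change on an aromatic carbon did not do. Activity here does not depend on keeping that nitrogen's hydrogen. Nothing available here accounts for the size of the step.

On these data alone, whether the sulfonyl link or the methoxyphenyl part carries the step remains open, and a methylsulfonyl or acetyl group on the same nitrogen would separate the two. Also open, as far as these compounds go, is whether the step holds with methyl in place of trifluoromethyl.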